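The compounds below may be only part of what the source reports. "The series", "measured", "known", "first", "only" and "open" are said of these compounds alone.

Measured compounds:
compound 1, `Cc1nc(S(C)(=O)=O)ccc1Oc1ncnc(OC2CCN(C(=O)O[C@H](C)CF)CC2)c1F`: 196 nM in a functional assay on isolated protein for inhibition of Glucose-dependent insulinotropic receptor (Homo sapiens), read by HTRF and cAMP accumulation; a higher number here means that more compound is needed for the effect, a lower number that less compound is needed
compound 2, `Cc1nc(S(C)(=O)=O)ccc1Oc1ncnc(OC2CCN(C(=S)OC(C)C)CC2)c1F`: 69.9 nM in this assay
compound 3, `Cc1nc(S(C)(=O)=O)ccc1Oc1ncnc(OC2CCN(C(=O)C3CCCC3)CC2)c1F`: 72.8 nM in this assay

Compound 3 holds the second highest of the three numbers. Its nearest neighbour is compound 2: a 1.0-fold higher number from compound 2 to compound 3 (0.02 log units; within the scatter). The only gap beyond the scatter is to compound 1: a 2.7-fold lower number from compound 1 to compound 3 (0.43 log units; beyond the scatter). Among the compounds with values here, compound 1 and compound 3 differ only at the carbonyl carbon, so that step is the single precedent for a change at this place. The step of a 2.8-fold lower number from compound 1 to compound 2 (0.45 log units; beyond the scatter) replaces the whole group on the ring nitrogen and bears on the carbonyl position only indirectly.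

Compound 4, `Cc1nc(S(C)(=O)=O)ccc1Oc1ncnc(OC2CCN(C(=O)C3(C)CC3)CC2)c1F`, differs from compound 3 by 1-methylcyclopropyl in place of cyclopentyl on a carbonyl carbon. Within the data shown here, the one precedent at the carbonyl carbon, a 2.7-fold lower number from compound 1 to compound 3 (0.43 log units; beyond the scatter), was modest, and the two exchanges on the ring nitrogen, a 2.8-fold lower number from compound 1 to compound 2 (0.45 log units; beyond the scatter) and a 1.0-fold higher number from compound 2 to compound 3 (0.02 log units; within the scatter), were modest or within the scatter. One carbon ring replacing another is a smaller alteration than any of those. For compound 4 the expected step is a 1.2-fold higher number from compound 3 to compound 4 (0.09 log units; within the scatter), not clearly beyond the scatter, if anything toward a slightly higher number. The estimate for compound 4 is 90 nM, with a range from 40 nM to 200 nM.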

Compound 4, half-maximal effective concentration: 761 nM
Compound 4: the middle estimate sits 8.5-fold (0.93 log units) below what was measured; measured number outside the range, above it.
By their numbers in this assay, from the lowest: compounds 2 and 3 (each within the scatter of the next); then compound 1; then compound 4.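

In this assay, within the data shown here, the carbonyl carbon proves sensitive to which carbon ring it carries: 1-methylcyclopropyl in place of cyclopentyl gives the largest step at this place so far (a 10-fold higher number from compound 3 to compound 4 (1.02 log units; beyond the scatter)), although neither group has a hydrogen-bond donor or acceptor. Among these compounds, a carbon ring at this place does not in itself give a lower number, as compound 1, which has no ring in its group, lies between the two ring compounds, with compound 3 on one side and compound 4 on the other (a 3.9-fold higher number from compound 1 to compound 4 (0.59 log units; beyond the scatter)), while the exchange of the whole group on the ring nitrogen of compound 2 gives a step of similar size to the one from compound 3 (an 11-fold higher number from compound 2 to compound 4 (1.04 log units; beyond the scatter)). Nothing available here bears on why this exchange has so large an effect.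

Ring size, the methyl on the ring and the change in heavy-atom count all change together in this one step, so cyclopropyl, cyclobutyl and 1-methylcyclopentyl on the same carbonyl carbon would be needed to tell them apart. As far as these compounds go, how an amine or a carboxylic acid on the cyclopentyl ring would read also remains open.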